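Benzyl ether to hydroxyethyl ether on a shared core

A few compounds are considered here, and "the series" means these few. Any claim that something is new, unique, unknown or untested is made for them only; others in the source may bear on it.

Compound 1 `C=CCn1cc(C(N)=S)c2c(N)ncnc21` gives 19000 nM in a functional assay on KB cells (Homo sapiens) for cytotoxicity; on this read-out higher numbers stand for weaker inhibition and lower numbers for stronger inhibition. Compound 2 `NC(=S)c1cn(COC(CO)CO)c2ncnc(N)c12` reaches only a limit of this assay, > 100000 nM. Compound 3 `NC(=S)c1cn(COCc2ccccc2)c2ncnc(N)c12` likewise stands at a limit of this assay, > 100000 nM. Compound 3 thus sits at the weak end of what this assay can report, as described by the limit of > 100000 nM in this assay, at which 2 of the 3 values shown sit. Compound 4 `NC(=S)c1cn(COCCO)c2ncnc(N)c12` differs from compound 3 in that (hydroxymethyl in place of phenyl on a saturated chain carbon bound to an oxygen on a saturated carbon). Among the measured compounds shown here, two measured steps bear on this change: an at least 5.2-fold higher number from compound 1 to compound 2 (0.72 log units; beyond the scatter), and a step that the two limits leave unreadable from compound 2 to compound 3. Since compound 2, which carries a related chain, already sits at a limit, compound 4 is expected to remain at or near that limit, an estimated a number no higher from compound 3 to compound 4 (the limit leaves the size open). In this assay compound 4 is therefore estimated at 100000 nM, within a range of 40000 nM to 300000 nM.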

Compound 4, half-maximal inhibitory concentration: 115000 nM
The estimate for compound 4 lay 1.2-fold (0.06 log units) below the measured number, and the stated range covers the measured number.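

With 2-hydroxyethyl in place of benzyl, this assay yields a readable number rather than a limit, so this chain can be sized against compound 1: the result is a 6.1-fold higher number from compound 1 to compound 4 (0.78 log units; beyond the scatter). The steps to compound 4 from compound 2 and from compound 3 cannot be read, as both of those compounds stand at a limit: the limit of > 100000 nM in this assay, at which 2 of the 4 values shown sit.

On these data alone, it remains open how compound 4 truly ranks against those two compounds. Also open, as far as these compounds go, is what an amine or a carboxylic acid in place of hydroxymethyl, or a longer chain, would give in this assay.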